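The source may hold more compounds than are shown below. What is called first, only, known or untested is meant among the compounds shown, and "the series" means these compounds.

Compound 1 `COc1ccc(N(CC(=O)NCCCSc2ccccc2)C(=O)CCSC2=C(C)C(=O)c3ccccc3C2=O)cc1` gives, in a functional assay on A-431 cells (Homo sapiens) for cytotoxicity, read by MTT assay, with a stated time of 24 h (on this read-out lower numbers stand for stronger inhibition and higher numbers for weaker inhibition), a value of 17000 nM. Compound 2 `COc1ccc(N(CC(=O)NCCC[Te]c2ccccc2)C(=O)CCSC2=C(C)C(=O)c3ccccc3C2=O)cc1` gives 1000 nM in this assay. The change between them, (a group of 7 heavy atoms (6 carbon, 1 tellurium; one six-membered aromatic ring of carbon only) in place of a group of 7 heavy atoms (6 carbon, 1 sulfur; one six-membered aromatic ring of carbon only), on a saturated chain carbon, three bonds along the chain from an amide-type nitrogen), produced a 17-fold lower number from compound 1 to compound 2 (1.23 log units; beyond the scatter).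

Compound 3 `COc1ccc(N(CC(=O)NCCCSc2ccccc2)C(=O)c2ccccc2)cc1` carries a different core; how its core differs from that of compound 1 is not broken down here. In this assay compound 3 reaches only a limit, >= 100000 nM, which is a limit of the assay and not a number, as the limit of >= 100000 nM in this assay, at which 1 of the 3 values shown sits, records.

Compound 4 `COc1ccc(N(CC(=O)NCCC[Te]c2ccccc2)C(=O)c2ccccc2)cc1` is still to be measured in this assay. It differs from compound 3 by a group of 7 heavy atoms (6 carbon, 1 tellurium; one six-membered aromatic ring of carbon only) in place of a group of 7 heavy atoms (6 carbon, 1 sulfur; one six-membered aromatic ring of carbon only), on a saturated chain carbon, three bonds along the chain from an amide-type nitrogen, the same change that separates compound 1 from compound 2. Because the first occurrence gave a 17-fold lower number from compound 1 to compound 2 (1.23 log units; beyond the scatter), a step of similar size is expected here, though the starting point of compound 3 is only a limit. Compound 4 is expected to give 30000 nM, between 5000 nM and 150000 nM. This estimate means an expected step of an at least 3.3-fold lower number from compound 3 to compound 4 (0.52 log units; beyond the scatter).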

Compound 4, half-maximal inhibitory concentration: 5000 nM
Compound 4: middle estimate off by 6.0-fold (0.78 log units), on the high side; measured number inside the range.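

In this assay, putting the tellurium group in place of phenylsulfanyl gave an at least 20-fold lower number from compound 3 to compound 4 (1.30 log units; beyond the scatter), so the change again lowered the number on a second core. Two cores are too few to establish a rule for the series, and the sizes of the two steps cannot be matched: the same change on two cores in this assay, a 17-fold lower number (1.23 log units; beyond the scatter) from compound 1 to compound 2 and an at least 20-fold lower number (1.30 log units; beyond the scatter) from compound 3 to compound 4; the limit leaves it open whether they differ Compound 3 stands at >= 100000 nM, which is a limit of the assay and not a number.

The compounds shown leave open whether selenium in place of tellurium would give a step of like size. They also leave open whether the change holds with a longer chain, or on a core carrying an amine.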